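Growing the side chain on a hydrazone-linked nitrothiazole core

The compounds below may be only part of what the source reports. "The series", "measured", "known", "first", "only" and "open" are said of these compounds alone.

Measured compounds:
- compound 1 `CC(C)=NNc1nc(-c2cccc([N+](=O)[O-])c2)cs1`: 716 nM
- compound 2 `CCC/C(C)=N\Nc1nc(-c2cccc([N+](=O)[O-])c2)cs1`: 55 nM
- compound 3 `C/C(CC(C)C)=N/Nc1nc(-c2cccc([N+](=O)[O-])c2)cs1`: 12 nM

All three share one core and differ only in the chain that hangs from the carbon with a double bond to nitrogen. In an assay on isolated protein for inhibition of Amine oxidase [flavin-containing] B (Homo sapiens), read by fluorescence, with a stated time of 20 min (a higher number here means a weaker inhibitor, a lower number a stronger inhibitor), compound 2 gives 55 nM, the second highest of the three numbers; compound 3 sits a 4.6-fold lower number from compound 2 to compound 3 (0.66 log units; beyond the scatter) away, and compound 1 is a 13-fold lower number from compound 1 to compound 2 (1.11 log units; beyond the scatter) away in the other direction.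

Compound 4 `CCC/C(CC)=N\Nc1nc(-c2cccc([N+](=O)[O-])c2)cs1` has not yet been measured. It differs from compound 2 by methyl in place of hydrogen on a saturated chain carbon bound to a carbon with a double bond to nitrogen.

Going by the values given here, three measured steps bear on this change. Going from compound 1 to compound 2, adding an ethyl group at this same position gave a 13-fold lower number from compound 1 to compound 2 (1.11 log units; beyond the scatter). Adding an isopropyl group instead gave a 60-fold lower number from compound 1 to compound 3 (1.78 log units; beyond the scatter). Adding a single methyl one bond further along the chain gave a 4.6-fold lower number from compound 2 to compound 3 (0.66 log units; beyond the scatter). Every enlargement of this chain so far has lowered the number, and the smaller additions have given the smaller shifts.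

A methyl added to compound 2 is therefore expected to give a modest lowering, estimated at a 2.8-fold lower number from compound 2 to compound 4 (0.44 log units; beyond the scatter). Compound 4 is thus estimated to reach 20 nM, with a likely range from 7 nM to 60 nM.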

Compound 4, half-maximal inhibitory concentration: 189 nM
Beside the measured number, compound 4's estimate is 9.5-fold (0.98 log units) below it; measured number above the stated range.
By their numbers in this assay, from the lowest: compound 3; then compound 2; then compound 4; then compound 1.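

In this assay the added methyl pushes the number up rather than down (a 3.4-fold higher number from compound 2 to compound 4 (0.54 log units; beyond the scatter)), so at this saturated chain carbon bound to a carbon with a double bond to nitrogen, methyl to ethyl is the one enlargement among these compounds that weakens inhibition. Chain growth from the smallest compound still pays off overall (a 3.8-fold lower number from compound 1 to compound 4 (0.58 log units; beyond the scatter)), but the gain is much smaller than for compound 3, whose differing group has the same count of heavy atoms as that of compound 4 (a 16-fold higher number from compound 3 to compound 4 (1.20 log units; beyond the scatter)), so that count alone does not set the number, and the simple rule that a larger chain gives a lower number fails at compound 4. Nothing available explains why the methyl has this effect.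

These compounds leave open whether the loss belongs to the ethyl alone or depends on the propyl chain on the same carbon, a question that a compound with two ethyl groups, or one pairing ethyl with the chain of compound 3, could address. On these data alone, it is also open how a ring such as cyclohexyl, or an amine at the end of a longer chain, would behave here.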